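This account rests on a few compounds, and the source may have more. Where it says the series, first, only, none or still open, it means among the compounds named here.

Three sulfamate compounds have so far been tested in an assay on HEK293 cells for inhibition of Steryl-sulfatase (Homo sapiens), tested at 0.1 uM; on this read-out lower numbers stand for a weaker effect and higher numbers for a stronger effect at the one concentration tested. Compound 1 `CCN(Cc1ccc(Br)cc1)c1ccc(C(=O)N2CCc3ccc(OS(N)(=O)=O)cc3C2)cc1` gives 78.2%, compound 2 `CCN(Cc1ccccc1)Cc1ccc(S(=O)(=O)N2CCc3ccc(OS(N)(=O)=O)cc3C2)cc1` gives 10%, and compound 3 `CCN(Cc1ccncc1)c1cccc(C(=O)N2CCc3ccc(OS(N)(=O)=O)cc3C2)c1` gives 33.3%. Compound 3 stands second highest of the three: compound 2 is its nearest neighbour and lies lower by a gap beyond the usual scatter, while compound 1 lies higher by a considerably larger gap, also beyond the scatter.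

Compound 4 `CC(C)CCN(CCC(C)C)c1cccc(C(=O)N2CCc3ccc(OS(N)(=O)=O)cc3C2)c1` has not yet been measured. It differs from compound 3 in one place: diisopentylamino in place of ethyl((pyridin-4-yl)methyl)amino on an aromatic carbon. Going by the values given here, no pair of measured compounds isolates such a change, so the direction must be judged loosely. Compound 3 keeps an amino group with an ethyl arm and an arylmethyl arm, as compound 1 does, whereas compound 4 carries two branched alkyl arms and no second ring.

A modest upward step is expected, a number 8.7 percentage points higher from compound 3 to compound 4 (within the scatter), though with wide uncertainty. Compound 4 is estimated at 42%, within a range from 12% to 75%.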

Compound 4, a percentage reported as inhibition, at one concentration (the size of the read-out at that concentration, not a potency): 32.3%
Compound 4: the middle estimate sits 9.7 percentage points above what was measured; the range from low to high includes it.
By their numbers in this assay, from the lowest: compound 2; then compounds 4 and 3 (each within the scatter of the next); then compound 1.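

In this assay, going by these compounds alone, the exchange of ethyl((pyridin-4-yl)methyl)amino for diisopentylamino on this aromatic carbon, meta to a large group, amounts to a number 1 percentage points lower from compound 3 to compound 4 (within the scatter) and is the first step that isolates one place. It shows that, for this pair, the read-out at the one concentration tested stays within the scatter when an arm holding a six-membered aromatic ring gives way to a group with no ring, so that ring is not needed to reach the level of compound 3. No measured property is available that bears on this result.

From the compounds shown here alone, it remains open whether a much shorter group such as dimethylamino, or a carboxylic acid, would read the same on this carbon. Going by these compounds, it is also open whether ethyl(4-bromobenzyl)amino, the kind of group carried by compound 1 at 78.2%, would keep that level here.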